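Aromatic substitution on the phenyl of compound 1

A few compounds are considered here, and "the series" means these few. Any claim that something is new, unique, unknown or untested is made for them only; others in the source may bear on it.

Compound 1 `CCOC(=O)C12C(=O)OCC=C1COC2c1ccccc1` is the parent of the pair measured so far. In a functional assay on HeLa cells (Homo sapiens) for cytotoxicity, read by MTT assay (a lower number here means a stronger inhibitor, a higher number a weaker inhibitor), compound 1 gives 12800 nM, the lower of the two numbers in hand. Compound 2 `CCOC(=O)C12C(=O)OCC=C1COC2c1ccccc1F` carries fluoro in place of hydrogen on an aromatic carbon; in this assay compound 2 gives 22100 nM. For the measured compounds named here, the step of a 1.7-fold higher number from compound 1 to compound 2 (0.24 log units; within the scatter) is the only measured step. Compound 3 `CCOC(=O)C12C(=O)OCC=C1COC2c1ccc(C(C)(C)C)cc1` differs from compound 1 by tert-butyl in place of hydrogen on an aromatic carbon. Only the fluoro step bears on this change, and it stayed within the scatter, so substitution on the aromatic ring has so far moved this assay little; tert-butyl is a different group from fluoro and nothing measured tells its own effect, so the expected step of a 1.1-fold higher number from compound 1 to compound 3 (0.04 log units; within the scatter) is none beyond the scatter. Compound 3 is therefore estimated at 14000 nM in this assay, with a range from 5000 nM to 40000 nM.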

Compound 3, half-maximal inhibitory concentration: 25400 nM
Estimate against measurement, compound 3: 1.8-fold (0.26 log units) below; the measured number falls inside the stated range.
By their numbers in this assay, from the lowest: compounds 1, 2 and 3 (each within the scatter of the next).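

In this assay the tert-butyl change is a 2.0-fold higher number from compound 1 to compound 3 (0.30 log units; within the scatter) and so stays within the scatter, even though it places 4 heavy atoms where compound 1 has only hydrogen. Together with the fluoro change, a 1.7-fold higher number from compound 1 to compound 2 (0.24 log units; within the scatter) and also within the scatter, it means that neither ring substitution shown so far has a clear effect on the number, whether the group is a single fluoro or the larger tert-butyl. No evidence on hand accounts for this result.

As far as these compounds go, whether an amine or a carboxylic acid on the same aromatic carbon would give a step beyond the scatter remains open. Also open, from the compounds shown here alone, is how the number responds to changes away from the phenyl, such as a longer chain in place of the ethyl of the ester.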